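This account rests on a few compounds, and the source may have more. Where it says the series, first, only, none or still open, it means among the compounds named here.

Working notes on the series. In an ADME assay on NHDF cells (Homo sapiens) for cytotoxicity, read by MTT assay, with a stated time of 72 h (a lower number here means a stronger inhibitor, a higher number a weaker inhibitor), compound 3 `COc1ccc(/C=C2\CCC/C(=C\c3ccc(Cl)cc3)C2=O)cc1OC` gives 11200 nM. Compound 1 `COc1cccc(/C=C2\CCC/C(=C\c3ccc(Cl)cc3)C2=O)c1OC` gives 18600 nM in this assay, and the two numbers shown, those of compound 3 and compound 1, lie within the scatter of each other, so no order between them is claimed. Compound 2 `COc1cccc(/C=C2\CCC/C(=C\c3cccc(Cl)c3Cl)C2=O)c1OC` reaches only the limit of this assay, > 50000 nM. Going by the values given here, the single measured step, 2,3-dichlorophenyl in place of 4-chlorophenyl, is an at least 2.6-fold higher number from compound 1 to compound 2 (0.42 log units; beyond the scatter); because it ends at the limit of > 50000 nM in this assay, at which 1 of the 3 values shown sits, its true size is not known.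

Compound 4 `COc1ccc(/C=C2\CCC/C(=C\c3cc(Cl)cc(Cl)c3)C2=O)cc1OC` is not yet measured in this assay. It differs from compound 3 by 3,5-dichlorophenyl in place of 4-chlorophenyl on a double-bonded chain carbon bound to a double-bonded ring carbon. The step from compound 1 to compound 2 is the only one that bears on it, since each change trades 4-chlorophenyl for a phenyl carrying two chlorines, though the two chlorines do not sit the same way in 2,3-dichlorophenyl and 3,5-dichlorophenyl, so the transfer is uncertain. A rise of the number beyond the scatter is expected for compound 4, about a 2.5-fold higher number from compound 3 to compound 4 (0.40 log units; beyond the scatter), with a real chance that only a limit is reported. Compound 4 is estimated at 28000 nM in this assay, with a range from 10000 nM to 70000 nM.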

Compound 4, half-maximal inhibitory concentration: 8300 nM
Compound 4: the middle estimate sits 3.4-fold (0.53 log units) above what was measured; the measured number lies below the stated range.
By their numbers in this assay, from the lowest: compounds 4, 3 and 1 (each within the scatter of the next, the first and the last beyond it). At a limit, above all of these: compound 2.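

In this assay, a second chlorine on this phenyl group does not by itself move the number: a 1.3-fold lower number from compound 3 to compound 4 (0.13 log units; within the scatter), so 3,5-dichlorophenyl and 4-chlorophenyl are not told apart here. The earlier step at the same place, an at least 2.6-fold higher number from compound 1 to compound 2 (0.42 log units; beyond the scatter), therefore does not describe every phenyl carrying two chlorines, and compound 4 goes against any reading that two chlorines on a double-bonded chain carbon raise the number. Compound 2 stands at a limit, not a number, and the step to it starts from a different parent, so its size cannot be set against that of the new step: the limit of > 50000 nM in this assay, at which 1 of the 4 values shown sits.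

The compounds shown do not separate the arrangement of the two chlorines from the difference between the parents of compound 1 and compound 3 as the source of the contrast between the two steps. They also leave open how this assay responds at this place when an amine or a carboxylic acid on the phenyl stands in place of chlorine.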